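Sulfonyl substituent variation in a factor X series

A few compounds are considered here, and "the series" means these few. Any claim that something is new, unique, unknown or untested is made for them only; others in the source may bear on it.

Measured compounds:
Compound 1, `O=C1[C@@H](NS(=O)(=O)c2nc3cc(Cl)ccc3[nH]2)CCN1Cc1cc2c[nH]ccc-2n1`, gives 31%.
Compound 2, `CC(C)(C)c1ccc(S(=O)(=O)N[C@H]2CCN(Cc3cc4c[nH]ccc-4n3)C2=O)cc1`, gives 14%.
Compound 3, `O=C1[C@@H](NS(=O)(=O)c2cc3ccc(Cl)nc3s2)CCN1Cc1cc2c[nH]ccc-2n1`, gives 51%.

All three share one core and differ only in the group on the sulfonyl sulfur, read in an assay on isolated protein for inhibition of coagulation factor X (Oryctolagus cuniculus), tested at 1 uM; on this read-out higher numbers stand for more inhibition at the one concentration tested (going by the name of the read-out) and lower numbers for less inhibition. Compound 3 stands highest of the three numbers; the step of a number 20 percentage points higher from compound 1 to compound 3 (beyond the scatter) and the step of a number 37 percentage points higher from compound 2 to compound 3 (beyond the scatter) both lie beyond the scatter, so the number for compound 3 is the highest of the measured set. The step of a number 17 percentage points lower from compound 1 to compound 2 (beyond the scatter) is modest.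

Compound 4, `O=C1[C@@H](NS(=O)(=O)c2cc3nc(Cl)ccc3s2)CCN1Cc1cc2c[nH]ccc-2n1`, is not yet measured. The change from compound 3 is a group of 10 heavy atoms (7 carbon, 1 nitrogen, 1 sulfur, 1 chlorine; one five-membered aromatic ring with 1 hetero atom, one six-membered aromatic ring with 1 hetero atom) in place of a group of 10 heavy atoms (7 carbon, 1 nitrogen, 1 sulfur, 1 chlorine; one five-membered aromatic ring with 1 hetero atom, one six-membered aromatic ring with 1 hetero atom), on a sulfonyl sulfur; the two have the same atoms, joined differently. Among the compounds with values here, no measured step concerns such a rearrangement within the bicyclic group: the two steps into compound 3 exchange the whole group for an unrelated one and say nothing about rearranging atoms within it. A step of no clear direction, possibly within the scatter, is therefore the expectation for this assay, with the chance of some loss kept in the range. Compound 4 is estimated at 44%, range 24% to 64%. The expected step from compound 3 is a number 7 percentage points lower from compound 3 to compound 4 (within the scatter).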

Compound 4, a percentage reported as inhibition, at one concentration (the size of the read-out at that concentration, not a potency): 58%
For compound 4 the middle estimate is 14 percentage points below the measured one; the range from low to high includes it.
By their numbers in this assay, from the lowest: compound 2; then compound 1; then compounds 3 and 4 (each within the scatter of the next).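

In this assay, within the data shown here, the step of a number 7 percentage points higher from compound 3 to compound 4 (within the scatter) is the first measured change that keeps the atoms of the bicyclic group on the sulfonyl sulfur and alters only how they are joined, and it leaves compound 3 and compound 4 within the scatter of each other. The step of a number 44 percentage points higher from compound 2 to compound 4 (beyond the scatter) against 4-(tert-butyl)phenyl and the step of a number 27 percentage points higher from compound 1 to compound 4 (beyond the scatter) against 5-chloro-1H-benzimidazol-2-yl run in the same direction as the steps into compound 3, so this direction holds for both arrangements of the bicyclic group. Nothing available bears on why the two arrangements read alike.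

On these data alone, whether the chlorine is needed on the bicyclic group remains open, as does the outcome of replacing it with a methoxy group or an amine, or of using a single-ring group such as chlorothiophene on the sulfonyl sulfur. A read-out at one concentration also leaves open how compound 3 and compound 4 compare in potency.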